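Shortening a phenoxy-bearing side chain on a saturated core

The compounds below may be only part of what the source reports. "The series", "measured", "known", "first", "only" and "open" are said of these compounds alone.

Three compounds share a bicyclic core carrying a thiazole carboxylic acid and a side chain that ends in a phenyl ether. Compound 2 `O=C(O)c1csc([C@H]2CC[C@@H]3[C@@H](/C=C/CCOc4ccccc4)[C@H](O)C[C@@H]3O2)n1` and compound 1 `O=C(O)c1csc([C@H]2CC[C@@H]3[C@@H](/C=C/COc4ccccc4)[C@H](O)C[C@@H]3O2)n1` both carry a double bond in that side chain; compound 3 `O=C(O)c1csc([C@H]2CC[C@@H]3[C@@H](CCCOc4ccccc4)[C@H](O)C[C@@H]3O2)n1` has the chain fully saturated. In a functional assay on CHO cells for agonist activity at prostaglandin E2 receptor EP3 subtype (Homo sapiens), read by fluorescence and calcium flux (a higher number here means that more compound is needed for the effect, a lower number that less compound is needed), compound 2 gives 260 nM, compound 1 gives 7600 nM, and compound 3 gives 5800 nM. The difference between the cores of compound 2 and compound 3 is not broken down here.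

Going from compound 2 to compound 1, the change is phenoxy in place of phenoxymethyl on a saturated chain carbon bound to a double-bonded chain carbon, and it produced a 29-fold higher number from compound 2 to compound 1 (1.47 log units; beyond the scatter). Compound 4 `O=C(O)c1csc([C@H]2CC[C@@H]3[C@@H](CCOc4ccccc4)[C@H](O)C[C@@H]3O2)n1` arises from compound 3 by phenoxy in place of phenoxymethyl on a saturated chain carbon, two bonds along the chain from a saturated ring carbon. This is the same kind of change, though its place differs: in compound 1 the altered carbon is bound to a double-bonded chain carbon, in compound 4 it sits two bonds along the chain from a saturated ring carbon. For compound 4 the step of a 4.3-fold higher number from compound 3 to compound 4 (0.63 log units; beyond the scatter) is expected in this assay, a weaker version of the earlier one, because compound 3 already gives 5800 nM and the earlier shortening pointed upward. Compound 4 is therefore estimated at 25000 nM, with a range from 5000 nM to 100000 nM.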

Compound 4, half-maximal effective concentration: 1400 nM
Estimate against measurement, compound 4: 18-fold (1.25 log units) above; measured number below the stated range.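

In this assay, swapping phenoxymethyl for phenoxy does not carry over from one core to the other: the saturated side chain gives a 4.1-fold lower number from compound 3 to compound 4 (0.62 log units; beyond the scatter), whereas the side chain with the double bond gives a 29-fold higher number from compound 2 to compound 1 (1.47 log units; beyond the scatter). Set side by side, the two results point in opposite directions and differ by more than ordinary scatter: the same change on two cores in this assay, a 29-fold higher number (1.47 log units; beyond the scatter) from compound 2 to compound 1 and a 4.1-fold lower number (0.62 log units; beyond the scatter) from compound 3 to compound 4, 120-fold (2.08 log units) apart, beyond the scatter of two such steps So in this series the effect of this change cannot be taken from one core and applied to the other, yet one pair per core does not show which difference between the cores decides the direction, and it says nothing about cores not shown here.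

The compounds shown leave open whether the double bond itself sets the direction of the step or some other difference between the two side chains does. They also leave open how a longer chain ending in the same phenyl ether, or an amine in place of the ether oxygen, would behave on either core.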